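Cyano to phenyl at the para position of compound 1

The source may report more compounds than this note shows. Statements on the series, on what has been measured and on what is new or still open speak of the compounds shown alone.

Compound 1 `N#Cc1ccc(-c2nc3sccn3c2/C=N/OCc2ccc(Cl)c(Cl)c2)cc1` is characterised in an assay on HepG2 cells for agonist activity at nuclear receptor subfamily 1 group I member 3 (Homo sapiens), read by a luciferase reporter, with a stated time of 23 h (a lower number here means that less compound is needed, a higher number that more compound is needed for the effect), where compound 1 gives 3400 nM. Among the two numbers available this is the higher one; the nearest entry is compound 2 `Fc1c(F)c(F)c(CO/N=C/c2c(-c3ccc4ccccc4c3)nc3occn23)c(F)c1F`, which in this assay gives 1700 nM, a gap that stays within the usual scatter, so no order between the two can be stated. Compound 3 `CC1(C)CCC(C)(C)c2cc(-c3nc4sccn4c3/C=N/OCc3ccc(Cl)c(Cl)c3)ccc21` in this assay gives "not active" (no number reported), with no number reported.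

Compound 4 `Clc1ccc(CO/N=C/c2c(-c3ccc(-c4ccccc4)cc3)nc3sccn23)cc1Cl` differs from compound 1 at one place: phenyl in place of cyano on an aromatic carbon. Within the data shown here, no step between measured compounds covers this exchange, so the direction rests on little. Compound 3, which carries a larger group at the same region of the core, gave no number in this assay, while compound 2 in this assay gives 1700 nM. For compound 4 the expected step from compound 1 is a 1.3-fold higher number from compound 1 to compound 4 (0.12 log units; within the scatter), a small loss if any, not clearly beyond the scatter. The estimate for compound 4 in this assay is 4500 nM, with a range from 1200 nM to 17000 nM.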

Compound 4, half-maximal effective concentration: "not active" (no number reported)
The entry for compound 4 holds no number; no gap can be computed for the estimate.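

Among these compounds, compound 4 gives no number in this assay and so no step from compound 1 can be read, and no measured evidence bears on this result. The compounds shown leave open how phenyl in place of cyano shifts the number, if at all.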